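A few compounds are considered here, and "the series" means these few. Any claim that something is new, unique, unknown or untested is made for them only; others in the source may bear on it.

Measured in a functional assay on SGC-7901 cells (Homo sapiens) for antiproliferative activity, read by MTT assay, with a stated time of 72 h; on this read-out lower numbers stand for stronger inhibition and higher numbers for weaker inhibition:
Compound 1 `CCOC(=O)c1cc(-c2cc(OC)c(OC)c(OC)c2)c(-c2ccc(OC)cc2)s1`: 9760 nM
Compound 2 `CCOC(=O)c1cc(-c2cc(OC)c(OC)c(OC)c2)c(-c2ccc(OC)c([N+](=O)[O-])c2)s1`: 18100 nM
Compound 3 `CCOC(=O)c1cc(-c2cc(OC)c(OC)c(OC)c2)c(-c2ccc3ccccc3c2)s1`: 4340 nM

Compound 1 sits in the upper part of this small set: the measurements show a 1.9-fold higher number from compound 1 to compound 2 (0.27 log units; within the scatter), and also a 2.2-fold lower number from compound 1 to compound 3 (0.35 log units; beyond the scatter). Compound 4 `COc1ccc(-c2sc(C(=O)O)cc2-c2cc(OC)c(OC)c(OC)c2)cc1` differs from compound 1 in one place, ethoxycarbonyl to carboxy: hydrogen in place of ethyl on an oxygen next to a carbonyl group. Among the compounds with values here, no measured step touches this group. The two steps above change another part of the molecule, so they offer only a scale. A modest step towards a higher number is therefore expected in this assay, although the data do not settle its direction. The expected change is a 2.3-fold higher number from compound 1 to compound 4 (0.35 log units; beyond the scatter). Compound 4 is estimated at 22000 nM, with an expected range from 7000 nM to 70000 nM.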

Compound 4, half-maximal inhibitory concentration: 7800 nM
Beside the measured number, compound 4's estimate is 2.8-fold (0.45 log units) above it, and the stated range covers the measured number.
By their numbers in this assay, from the lowest: compounds 3, 4, 1 and 2 (each within the scatter of the next, the first and the last beyond it).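

Hydrogen in place of ethyl on an oxygen next to a carbonyl group, the first change shown at this position, gives a 1.3-fold lower number from compound 1 to compound 4 (0.10 log units; within the scatter) in this assay. The ethyl group can therefore be lost, and ethoxycarbonyl can give way to carboxy, without a shift beyond the scatter in this assay. Nothing measured here offers an explanation for this result.

The compounds shown leave open whether a methyl ester, a longer chain on this oxygen or an amide would also hold the number. They also leave open whether carboxy is tolerated alongside the naphthalen-2-yl group of compound 3.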